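Replacing the Weinreb-type amide with an ester in the series

The source may hold more compounds than are shown below. What is called first, only, known or untested is meant among the compounds shown, and "the series" means these compounds.

Measured so far:
compound 1, `CCOC(=O)C[C@H]1[C@@H](O[Si](C)(C)C(C)(C)C)[C@H](n2cnc3c(NC(=O)Nc4ccccc4)ncnc32)O[C@@H]1COC(=O)NC`: 9.58 nM
compound 2, `CNC(=O)NC[C@H]1O[C@@H](n2cnc3c(NC(=O)Nc4ccccc4)ncnc32)[C@H](O[Si](C)(C)C(C)(C)C)[C@@H]1CC(=O)N(C)OC`: 11.1 nM

Two compounds have been run in a functional assay on NCI-H522 cells (Homo sapiens) for antiproliferative activity; a higher number here means a weaker inhibitor of growth, a lower number a stronger inhibitor of growth. Compound 2 gives 11.1 nM, the higher of the two numbers, but its nearest neighbour is compound 1 at 9.58 nM, and the gap between them lies within the scatter of repeated runs; no order between the two can be read from these numbers.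

The next compound, compound 3, `CCOC(=O)C[C@H]1[C@@H](O[Si](C)(C)C(C)(C)C)[C@H](n2cnc3c(NC(=O)Nc4ccccc4)ncnc32)O[C@@H]1CNC(=O)NC`, takes one step away from compound 2: ethoxy in place of methoxy(methyl)amino on a carbonyl carbon. Compound 1, which already carries the (ethoxycarbonyl)methyl group that enters here, gives 9.58 nM, so the group is not new to the series.

Going by the values given here, no measured pair in this set isolates the change from compound 2 to compound 3, so the size of the step cannot be taken from a measured step. Given that compound 1 with the same ethoxycarbonyl group sits at 9.58 nM, the expected step from compound 2 to compound 3 in this assay is a 1.1-fold lower number from compound 2 to compound 3 (0.05 log units; within the scatter), in neither direction beyond the scatter. Compound 3 is estimated to give 10 nM in this assay, with a range from 4 nM to 25 nM.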

Compound 3, concentration for 50% growth inhibition: 4.36 nM
The estimate for compound 3 lay 2.3-fold (0.36 log units) above the measured number; the range from low to high includes it.
By their numbers in this assay, from the lowest: compound 3; then compounds 1 and 2 (each within the scatter of the next).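

In this assay, ethoxy in place of methoxy(methyl)amino on a carbonyl carbon gives a 2.5-fold lower number from compound 2 to compound 3 (0.41 log units; beyond the scatter), so with the rest of the structure held fixed, the group on this carbonyl carbon moves the number beyond the scatter. With the (ethoxycarbonyl)methyl group held fixed, (methylcarbamoyl)amino in place of (methylcarbamoyl)oxy on a saturated chain carbon bound to a saturated ring carbon gives a 2.2-fold lower number from compound 1 to compound 3 (0.34 log units; beyond the scatter), so a second place on the shared core also responds, and compound 3 now has the lowest number of the three. Nothing available here gives a reason for either step.

Going by these compounds, each step rests on a single pair, so it remains open whether the ethoxy step would hold with (methylcarbamoyl)oxy in place of (methylcarbamoyl)amino. On these data alone, it is also open how a carboxylic acid, a primary amide or a longer chain such as propoxy on the same carbonyl carbon would read in this assay.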